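A methyl branch on the acid-bearing side chain

A few compounds are considered here, and "the series" means these few. Any claim that something is new, unique, unknown or untested is made for them only; others in the source may bear on it.

Compound 1 `O=C(O)CN1Cc2ccc(NC(=O)CCCC3CCNCC3)cc2C1=O` — 66000 nM
Compound 2 `O=C(O)CN1Cc2ccc(NC(=O)CC3CCNCC3)cc2C1=O` — 51000 nM
Compound 3 `O=C(O)CN1Cc2ccc(NC(=O)c3ccc(C4CCNCC4)cc3)cc2C1=O` — 24000 nM

Of the compounds shown here, three with a shared core have been tested in a functional assay on a cell-free system (Platelet, plasma, Homo sapiens) for inhibition; a lower number here means a stronger inhibitor, a higher number a weaker inhibitor. Compound 1 gives 66000 nM, the highest number of the three, so it is the weakest inhibitor in this set; its gap to compound 3 lies beyond the usual scatter, while its gap to compound 2 lies within it. Among the compounds with values here, the only single-site step among the measured compounds is a 1.3-fold lower number from compound 1 to compound 2 (0.11 log units; within the scatter), a change in the chain that links the piperidine to the amide carbonyl, and it changed the number by no more than the scatter.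

Compound 4 `CC(CC(=O)O)N1Cc2ccc(NC(=O)CCCC3CCNCC3)cc2C1=O` is not yet measured. It differs from compound 1 at the other end of the molecule: 1-(carboxymethyl)ethyl in place of carboxymethyl on an amide-type nitrogen in a ring. Within the data shown here, none of the measured steps touches this position, so no measured step bears directly on the change. Among the measured compounds shown here, the one step that is known, from the amide side, stayed within the scatter. With nothing to point in either direction, the expectation for compound 4 in this assay is a step of no more than the scatter, no change at the digits printed from compound 1 to compound 4 (within the scatter). Compound 4 is therefore estimated at 66000 nM, with a range from 25000 nM to 170000 nM.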

Compound 4, half-maximal inhibitory concentration: 5400 nM
Beside the measured number, compound 4's estimate is 12-fold (1.09 log units) above it, outside the stated range (below it).
By their numbers in this assay, from the lowest: compound 4; then compound 3; then compounds 2 and 1 (each within the scatter of the next).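

In this assay, within the data shown here, the nitrogen side chain is the first place in this set where a single change moves the number beyond the scatter: 1-(carboxymethyl)ethyl in place of carboxymethyl gives a 12-fold lower number from compound 1 to compound 4 (1.09 log units; beyond the scatter) and makes compound 4 the lowest number so far. By the counts, the entering group has 6 heavy atoms against 4 for the leaving group, all of the extra ones carbon, while the hydrogen-bond donor and acceptor counts stay the same and neither group has a ring or a net charge, so a change of carbon alone at this position is enough for a large step. Nothing measured here shows how this carbon change acts on the number.

The entering group adds a methyl branch and also lengthens the chain that carries the carboxylic acid, so an unbranched 2-carboxyethyl group and a shorter branched 1-carboxyethyl group would be needed to tell those two features apart. On these data alone, it also remains open whether the same change would lower the number with the other amide side chains, those of compound 2 and compound 3.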